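Hydroxamic acids on MCF7 cells: furan for thiophene

A few compounds are considered here, and "the series" means these few. Any claim that something is new, unique, unknown or untested is made for them only; others in the source may bear on it.

Of the compounds shown here, two carry numbers so far. Compound 1 `Cc1ccc(-c2nnc(NC(=O)CCCCCCC(=O)NO)s2)s1` holds the lower of the two: in a functional assay on MCF7 cells (Homo sapiens) for inhibition, read by MTT assay (on this read-out higher numbers stand for weaker inhibition and lower numbers for stronger inhibition), compound 1 gives 880 nM. Compound 2 `CC(C)=CCC/C(C)=C/CC/C(C)=C/CSc1ccccc1C(=O)NCCCC(=O)NO` is built on a different scaffold with a shorter chain to the hydroxamic acid, and in this assay compound 2 gives 4930 nM. The gap between the two lies beyond the usual scatter, so compound 1 stands as the stronger inhibitor of the pair. Among the compounds with values here, no two measured compounds differ in only one place, so no single structural step has yet been measured.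

Compound 3 `Cc1ccc(-c2nnc(NC(=O)CCCCCCC(=O)NO)s2)o1` is the next member awaiting a number. Compound 3 carries 5-methylfuran-2-yl in place of 5-methylthiophen-2-yl on an aromatic carbon. The hydroxamic acid, the chain and the shared core of compound 1 are unchanged; only the ring attached to the core swaps its hetero atom.

Within the data shown here, with no measured step of this kind to lean on, the step of a 1.3-fold higher number from compound 1 to compound 3 (0.10 log units; within the scatter) is expected to be small, within the usual scatter, with at most a slight drift toward a higher number. Compound 3 is therefore estimated at 1100 nM, with a range from 400 nM to 3000 nM.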

Compound 3, half-maximal inhibitory concentration: 880 nM
Compound 3: middle estimate off by 1.3-fold (0.10 log units), on the high side; low and high end bracket the measured number.
By their numbers in this assay, from the lowest: compounds 1 and 3 (each within the scatter of the next); then compound 2.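

Within the data shown here, this is the first step that differs in one place only. On an aromatic carbon of the shared core, 5-methylfuran-2-yl in place of 5-methylthiophen-2-yl gives, in this assay, no change at the digits printed from compound 1 to compound 3 (within the scatter), so this exchange of the ring's hetero atom, sulfur for oxygen, leaves the read-out within the scatter while the hydroxamic acid and the chain stay fixed. Nothing measured on these two rings bears on this result, and the reading stays a plain observation on one pair of compounds.

The compounds shown leave open whether this position keeps its number with a group of another kind, such as a phenyl ring, a ring bearing an amine or a carboxylic acid, or a thiophene or furan without the methyl group. They also leave open how a shorter or longer chain to the hydroxamic acid would read on the core of compound 1, and whether the furan and thiophene would still match on such a chain.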